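Working notes on compound 4 and its three neighbours

The source may hold more compounds than are shown below. What is called first, only, known or untested is meant among the compounds shown, and "the series" means these compounds.

Values in an ADME assay on HEK293 cells (Homo sapiens) for cytotoxicity, read by MTT assay, with a stated time of 48 h; a higher number here means a weaker inhibitor, a lower number a stronger inhibitor:
- Compound 1 `COc1ccc(-c2cn3cc(C4=CCN(C(=O)c5ccccc5C(F)(F)F)CC4)ccc3n2)cc1OC` gives 82900 nM
- Compound 2 `COc1ccc(-c2cn3cc(C4=CCN(S(=O)(=O)c5ccccc5)CC4)ccc3n2)cc1OC` gives 65600 nM
- Compound 3 `COc1ccc(-c2cn3cc(C4=CCN(S(=O)(=O)C5CCCC5)CC4)ccc3n2)cc1OC` gives 103000 nM

Compound 3 has the highest of the three numbers, yet the steps of a 1.2-fold higher number from compound 1 to compound 3 (0.09 log units; within the scatter) and a 1.6-fold higher number from compound 2 to compound 3 (0.20 log units; within the scatter) both sit within the scatter, so the three compounds cannot be ordered. Compound 4 `COc1ccc(-c2cn3cc(C4=CCN(S(=O)(=O)CCc5ccccc5)CC4)ccc3n2)cc1OC` differs from compound 3 by phenethyl in place of cyclopentyl on a sulfonyl sulfur. The step that bears on it most directly, a 1.6-fold higher number from compound 2 to compound 3 (0.20 log units; within the scatter), swapped groups on the same sulfonyl sulfur and stayed within the scatter; a 1.3-fold lower number from compound 1 to compound 2 (0.10 log units; within the scatter), a larger change at the ring nitrogen, did likewise. No step beyond the scatter is therefore expected, a 1.2-fold lower number from compound 3 to compound 4 (0.08 log units; within the scatter). Compound 4 is estimated at 85000 nM, within 40000 nM to 180000 nM.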

Compound 4, half-maximal inhibitory concentration: 70300 nM
Beside the measured number, compound 4's estimate is 1.2-fold (0.08 log units) above it; low and high end bracket the measured number.
By their numbers in this assay, from the lowest: compounds 2, 4, 1 and 3 (each within the scatter of the next).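

In this assay, phenethyl on a sulfonyl sulfur gives no readable change against cyclopentyl (a 1.5-fold lower number from compound 3 to compound 4 (0.17 log units; within the scatter)) or against phenyl (a 1.1-fold higher number from compound 2 to compound 4 (0.03 log units; within the scatter)), so a group with a chain before its aromatic ring also stays within the scatter at this position. The comparison with the carbonyl-linked compound reads the same (a 1.2-fold lower number from compound 1 to compound 4 (0.07 log units; within the scatter)), leaving all four compounds unordered. No measurement offers an explanation for this flat picture. From the compounds shown here alone, whether an amine or a carboxylic acid on that ring, or a chain longer than phenethyl, would give a step beyond the scatter remains open.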